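Swapping a Sulfonamide for an Amide on a Weak Scaffold

This account rests on a few compounds, and the source may have more. Where it says the series, first, only, none or still open, it means among the compounds named here.

Compound 1 `CCOC(=O)[C@@H]1CCCN(S(=O)(=O)c2ccc(S(=O)(=O)N(CC)C(C)C)cc2)C1` was tested in a functional assay on MIA PaCa-2 cells (Homo sapiens) for inhibition, read by MTT assay, with a stated time of 3 days; a higher number here means a weaker inhibitor, a lower number a stronger inhibitor. In this assay compound 1 reaches only the limit > 10000 nM, so no number is known for it. Compound 2 `CCOC(=O)[C@@H]1CCCN(S(=O)(=O)c2ccc(S(=O)(=O)N(CC)CC)cn2)C1` likewise stops at the limit > 10000 nM in this assay. Both values therefore sit at the same edge of what the assay can report, as seen in the limit of > 10000 nM in this assay, at which 2 of the 2 values shown sit, and compound 1 stands nowhere distinct among them.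

Compound 3 `CCOC(=O)[C@@H]1CCCN(S(=O)(=O)c2ccc(C(=O)N(CC)CC)cc2)C1` has not yet been measured. It differs from compound 1 by diethylcarbamoyl in place of ethyl(isopropyl)sulfamoyl on an aromatic carbon. For the measured compounds named here, no measured step links compound 1 to compound 3, so the expected step from compound 1 to compound 3 in this assay is a step that the limit leaves unreadable from compound 1 to compound 3, which is no change beyond the usual scatter. Compound 3 is therefore expected to give about 15000 nM in this assay, within a range of 3000 nM to 60000 nM, most likely reported again as a limit.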

Compound 3, half-maximal inhibitory concentration: > 10000 nM
Compound 3: no number, only a limit; the forecaster's own chance of this, stated with the estimate: 80%; the middle value lies beyond the limit too.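

Compound 1 and compound 3 each reach only a limit, so no step between them can be read: the limit of > 10000 nM in this assay, at which 3 of the 3 values shown sit.

In this assay the compounds shown leave open whether any change to the shared core would give a true number instead of a limit.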